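The compounds below may be only part of what the source reports. "The series", "measured", "known", "first", "only" and "open" are said of these compounds alone.

Measured compounds, with their values in an assay for inhibition of Amine oxidase [flavin-containing] B (Homo sapiens), read by fluorescence, using microsomes, with a stated time of 30 min; on this read-out lower numbers stand for stronger inhibition and higher numbers for weaker inhibition:
Compound 1 `CN(C)Cc1cc(=O)oc2cc(OCc3ccc(CO)cc3)ccc12`: 630 nM
Compound 2 `CN(C)Cc1cc(=O)oc2cc(OCc3cccc(CO)c3)ccc12`: 1100 nM
Compound 3 `Cc1cc(=O)oc2cc(OCC3CCN(Cc4ccc(CO)cc4)CC3)ccc12`: 600 nM

Compound 1 and compound 2 share one core and differ only by 3-(hydroxymethyl)phenyl in place of 4-(hydroxymethyl)phenyl on a saturated chain carbon bound to an oxygen on an aromatic ring; this change gave a 1.7-fold higher number from compound 1 to compound 2 (0.24 log units; within the scatter). Compound 3 carries a different core, and the difference between the two cores is not broken down here. Compound 4 `Cc1cc(=O)oc2cc(OCC3CCN(Cc4cccc(CO)c4)CC3)ccc12`, not yet measured, is derived from compound 3 by 3-(hydroxymethyl)phenyl in place of 4-(hydroxymethyl)phenyl on a saturated chain carbon bound to an amine nitrogen in a ring. This is the same kind of change as between compound 1 and compound 2, but not the same: there the place was on a saturated chain carbon bound to an oxygen on an aromatic ring, here it is on a saturated chain carbon bound to an amine nitrogen in a ring. Because the earlier change gave a 1.7-fold higher number from compound 1 to compound 2 (0.24 log units; within the scatter), a step of similar size is expected here, estimated at a 1.7-fold higher number from compound 3 to compound 4 (0.22 log units; within the scatter). Compound 4 is therefore expected to give about 1000 nM in this assay, most likely between 500 nM and 2200 nM.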

Compound 4, half-maximal inhibitory concentration: 480 nM
The estimate for compound 4 lay 2.1-fold (0.32 log units) above the measured number; measured number outside the range, below it.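

In this assay, putting 3-(hydroxymethyl)phenyl in place of 4-(hydroxymethyl)phenyl on the core of compound 3 gave a 1.3-fold lower number from compound 3 to compound 4 (0.10 log units; within the scatter). Set beside the same change on the core of compound 1, the two steps cannot be told apart: the same change on two cores in this assay, a 1.7-fold higher number (0.24 log units; within the scatter) from compound 1 to compound 2 and a 1.3-fold lower number (0.10 log units; within the scatter) from compound 3 to compound 4, 2.2-fold (0.34 log units) apart, within the scatter of two such steps. Going by these compounds alone, this shows that the swap stayed within the scatter on both cores, but it does not show that the step has the same size or direction on each, as each core offers only one pair of compounds.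

Still open, on these data alone, is what happens with another group in place of hydroxymethyl, such as an amine, a carboxylic acid or a longer chain. Two cores are also too few to predict the change on a third.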